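The source may report more compounds than this note shows. Statements on the series, on what has been measured and on what is new or still open speak of the compounds shown alone.

The measured compounds, all tested in a functional assay on HT-29 cells (Homo sapiens) for cytotoxicity, read by MTT assay, with a stated time of 72 h; a lower number here means a stronger inhibitor, a higher number a weaker inhibitor:

- compound 1, `CN(C)CCn1cnnc1-c1cc(Oc2ccc(NC(=O)N/N=C/c3cc(C(C)(C)C)cc(C(C)(C)C)c3O)cc2F)ccn1`, gives 680 nM
- compound 2, `Cn1ncnc1-c1cc(Oc2ccc(NC(=O)N/N=C/c3ccccc3)cc2F)ccn1`, gives 30200 nM
- compound 3, `CN(C)CCn1cnnc1-c1cc(Oc2ccc(NC(=O)N/N=C/c3ccc(F)cc3)cc2F)ccn1`, gives 1370 nM

Among these three numbers, compound 3 has the second highest. Its nearest neighbour is compound 1, and the two values lie within the usual scatter of each other, so no difference between them can be claimed. The furthest is compound 2, whose number is far higher, beyond the scatter; compound 2 also differs from compound 3 in more than one place, so that gap is not tied to a single change.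

The unmeasured compound 4, `COc1cc(/C=N/NC(=O)Nc2ccc(Oc3ccnc(-c4nncn4CCN(C)C)c3)c(F)c2)ccc1O`, differs from compound 3 in one place: 4-hydroxy-3-methoxyphenyl in place of 4-fluorophenyl on a carbon with a double bond to nitrogen. Among the measured compounds shown here, no measured pair shows this particular exchange, so there is no step to lean on. The expectation is a step of a 1.4-fold lower number from compound 3 to compound 4 (0.14 log units; within the scatter), that is, no change beyond the scatter in this assay. Compound 4 is therefore estimated at 1000 nM, with a range from 250 nM to 4000 nM.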

Compound 4, half-maximal inhibitory concentration: 120 nM
The estimate for compound 4 lay 8.3-fold (0.92 log units) above the measured number; the whole stated range lies above it.
By their numbers in this assay, from the lowest: compound 4; then compounds 1 and 3 (each within the scatter of the next); then compound 2.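

In this assay the group on the carbon with a double bond to nitrogen turns out to matter a great deal: 4-hydroxy-3-methoxyphenyl in place of 4-fluorophenyl gives an 11-fold lower number from compound 3 to compound 4 (1.06 log units; beyond the scatter), with the rest of the molecule unchanged. Among the compounds shown here, the earlier compounds offered no single-place comparison, so this is the first direct sign that this group can shift the number by more than the scatter. The ring itself stays the same in the exchange, so the step goes with what is attached to it, though nothing shown explains why a step of this size occurs.

On these data alone, the exchange removes the fluorine and brings in a hydroxyl and a methoxy together, so their separate shares stay unknown. A plain 4-hydroxyphenyl, a plain 3-methoxyphenyl or a 4-aminophenyl group would help to separate them.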